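Replacing a chain on the aromatic oxygen with a carbonyl group

This account rests on a few compounds, and the source may have more. Where it says the series, first, only, none or still open, it means among the compounds named here.

Of the compounds shown here, three sharing one core have been measured in a functional assay for inhibition of Vanilloid receptor (Rattus norvegicus); a lower number here means a stronger inhibitor, a higher number a weaker inhibitor. Compound 1 `COc1cc(C(C)(C)C)ccc1C/N=C(\S)NCc1ccc(NS(C)(=O)=O)cc1` gives 2400 nM. Compound 2 `CCCCCOc1cc(C(C)(C)C)ccc1C/N=C(\S)NCc1ccc(NS(C)(=O)=O)cc1` gives 70 nM, and compound 3 `COCCOc1cc(C(C)(C)C)ccc1C/N=C(\S)NCc1ccc(NS(C)(=O)=O)cc1` gives 60 nM. Compound 3 has the lowest of the three numbers; its nearest neighbour is compound 2, at a gap that sits within the scatter, and its furthest is compound 1, at a gap that lies well beyond it. Two large steps describe what was learned: a 34-fold lower number from compound 1 to compound 2 (1.54 log units; beyond the scatter) and a 40-fold lower number from compound 1 to compound 3 (1.60 log units; beyond the scatter). The remaining step, a 1.2-fold lower number from compound 2 to compound 3 (0.07 log units; within the scatter), shows that the two longer groups on that oxygen are not told apart in this assay.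

Compound 4 `CC(C)(C)C(=O)Oc1cc(C(C)(C)C)ccc1C/N=C(\S)NCc1ccc(NS(C)(=O)=O)cc1` is not yet measured. It differs from compound 3 as follows: (tert-butyl)carbonyl in place of 2-methoxyethyl on an oxygen on an aromatic ring. Among the measured compounds shown here, both measured large steps concern lengthening a chain on the same oxygen, whereas here a group with a carbonyl takes the place of that chain; no measured step bears directly on such a swap. The group entering is larger than hydrogen, which in compound 1 gave 2400 nM, so compound 4 is expected to stay nearer to compound 3 than to compound 1, with a step of about a 2.5-fold higher number from compound 3 to compound 4 (0.40 log units; beyond the scatter) foreseen. The estimated value for compound 4 in this assay is 150 nM, with a range from 40 nM to 800 nM.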

Compound 4, half-maximal inhibitory concentration: 220 nM
Compound 4: middle estimate off by 1.5-fold (0.17 log units), on the low side, within the range that was stated.
By their numbers in this assay, from the lowest: compounds 3 and 2 (each within the scatter of the next); then compound 4; then compound 1.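

In this assay, the oxygen on the aromatic ring accepts a group bearing a carbonyl as well as an ether chain: (tert-butyl)carbonyl in place of methyl still gives a large gain (an 11-fold lower number from compound 1 to compound 4 (1.04 log units; beyond the scatter)), although this falls short of the gain seen with either chain. Among the compounds shown here, compound 4 is set apart from both chain compounds, by a 3.7-fold higher number from compound 3 to compound 4 (0.56 log units; beyond the scatter) and by a 3.1-fold higher number from compound 2 to compound 4 (0.50 log units; beyond the scatter), so this change is the first on this oxygen to separate two of the larger groups, whereas pentyl and 2-methoxyethyl could not be told apart. The compounds shown therefore place the larger groups at more than one level, but nothing presented here accounts for the shortfall of compound 4.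

(Tert-butyl)carbonyl differs from both chains in carrying a carbonyl and in its branching, so the compounds shown leave open which of these features goes with the modest steps. As far as these compounds go, a straight pentanoyl group and a 2,2-dimethylpropyl ether on the same oxygen would separate the two, and it also remains open how a carbamate or a longer chain would compare.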